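This account rests on a few compounds, and the source may have more. Where it says the series, first, only, none or still open, it means among the compounds named here.

Measured so far in a functional assay on DU-145 cells (Homo sapiens) for antiproliferative activity, read by MTT assay, with a stated time of 48 h; on this read-out lower numbers stand for stronger inhibition and higher numbers for weaker inhibition:

compound 1, `COc1cc(O)ccc1N1CCN(CC(O)COc2cccc3ccccc23)CC1`: 17200 nM
compound 2, `COc1cc(O)ccc1N1CCN(CC(O)COc2ccc(O)c3ccccc23)CC1`: a limit only, > 50000 nM
compound 3, `Oc1ccccc1N1CCN(CC(O)COc2ccc(O)c3ccccc23)CC1`: a limit only, > 50000 nM

Within the data shown here, two of the three values sit at the same limit, (the limit of > 50000 nM in this assay, at which 2 of the 3 values shown sit), so only one number is in hand. Among the measured compounds shown here, the one readable step is an at least 2.9-fold lower number from compound 2 to compound 1 (0.46 log units; beyond the scatter), made by hydrogen in place of hydroxy on an aromatic carbon. The cores differ by 2-hydroxyphenyl in place of 4-hydroxy-2-methoxyphenyl on an amine nitrogen in a ring, and the corresponding step is a step that the two limits leave unreadable from compound 2 to compound 3, since both values are limits.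

Compound 4, `Oc1ccccc1N1CCN(CC(O)COc2cccc3ccccc23)CC1`, differs from compound 3 by hydrogen in place of hydroxy on an aromatic carbon. The place is described in the same words as for the change from compound 2 to compound 1, so it is the same change on the other core.

For compound 4 a step of an at least 2.0-fold lower number from compound 3 to compound 4 (0.30 log units; that floor lies within the scatter) is expected, resting on the earlier step of an at least 2.9-fold lower number from compound 2 to compound 1 (0.46 log units; beyond the scatter), which gives only a lower bound to how large the step is. The estimate for compound 4 in this assay is 25000 nM, expected to fall between 8000 nM and 60000 nM, with a real chance that the assay again returns only a limit.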

Compound 4, half-maximal inhibitory concentration: 18000 nM
Compound 4: middle estimate off by 1.4-fold (0.14 log units), on the high side; the range from low to high includes it.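

In this assay, hydrogen in place of hydroxy on the aromatic carbon gives an at least 2.7-fold lower number from compound 3 to compound 4 (0.44 log units; beyond the scatter), and the change lowers the number on both cores: the same change on two cores in this assay, an at least 2.9-fold lower number (0.46 log units; beyond the scatter) from compound 2 to compound 1 and an at least 2.7-fold lower number (0.44 log units; beyond the scatter) from compound 3 to compound 4; the limit leaves it open whether they differ.
This supports carrying the change from one core to the other as a direction with a floor on its size, but not as a measured size, since compound 2 and compound 3 both give only a limit: the limit of > 50000 nM in this assay, at which 2 of the 4 values shown sit.
With hydrogen on that carbon, the exchange of the aryl group on the amine nitrogen gives a 1.0-fold higher number from compound 1 to compound 4 (0.02 log units; within the scatter), while the same exchange with the hydroxy present cannot be read.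

The series shown holds only hydrogen and hydroxy at this place and only two groups on the amine nitrogen, so it remains open whether an amine or a carboxylic acid at that carbon would fit the same direction. Also open, as far as these compounds go, is whether a longer chain between the amine nitrogen and the fused ring system would leave the step intact.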